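Bromo to Iodo: One Halogen Swap, One Expectation

A few compounds are considered here, and "the series" means these few. Any claim that something is new, unique, unknown or untested is made for them only; others in the source may bear on it.

compound 1 `COc1ccccc1N1CCN(CCCNC(=O)NN(Cc2ccccc2F)c2ccc(Br)cc2)CC1`: 3.3 nM
compound 2 `O=C(NCCN1CCN(c2ccc(Br)cc2)CC1)NN(Cc1ccccc1)c1ccccc1`: 28 nM

In an assay on CHO cells for displacement of a labelled ligand from D(4) dopamine receptor (Homo sapiens), read by radioligand binding (on this read-out higher numbers stand for weaker inhibition and lower numbers for stronger inhibition), compound 1 gives 3.3 nM, while compound 2 gives 28 nM. Compound 2 thus stands at the higher of the two numbers, and its gap to compound 1 lies beyond the usual scatter; the two structures differ in several places at once, so nothing in that gap isolates a single change.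

Compound 3 `O=C(NCCN1CCN(c2ccc(I)cc2)CC1)NN(Cc1ccccc1)c1ccccc1` differs from compound 2 by iodo in place of bromo on an aromatic carbon. For the measured compounds named here, no measured pair shows this swap alone. The expected step is a 1.1-fold lower number from compound 2 to compound 3 (0.05 log units; within the scatter), none beyond the scatter. For compound 3 the estimate is 25 nM, ranging from 8 nM to 80 nM.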

Compound 3, inhibition constant: 44 nM
For compound 3 the middle estimate is 1.8-fold (0.25 log units) below the measured one; the range from low to high includes it.
By their numbers in this assay, from the lowest: compound 1; then compounds 2 and 3 (each within the scatter of the next).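

In this assay, the change from 4-bromophenyl to 4-iodophenyl gives a 1.6-fold higher number from compound 2 to compound 3 (0.20 log units; within the scatter), so at this position on the aromatic ring the two halogens cannot be told apart. The earlier compounds shown here differed in several places at once and could not show this change alone. Nothing measured here offers an explanation for the result. From the compounds shown here alone, whether chloro, methoxy or an amine on this carbon would read like bromo and iodo remains open. So does whether the same swap would read alike on a compound with a longer chain.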